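The compounds below may be only part of what the source reports. "The series", "measured", "known", "first", "only" and "open" are said of these compounds alone.

Measured so far in an ADME assay on L02 cells (Homo sapiens) for cytotoxicity, read by MTT assay, with a stated time of 24 h (a lower number here means a stronger inhibitor, a higher number a weaker inhibitor), for two compounds
Compound 1 `CN1C/C(=C\c2ccncc2)C(=O)/C(=C/c2ccccc2F)C1` gives 14900 nM
Compound 2 `O=C1/C(=C/c2ccncc2)CN(S(=O)(=O)c2ccccc2)C/C1=C\c1ccccc1F` gives 15900 nM

For the measured compounds named here, compound 2 stands level with compound 1, the only other compound measured, since the two values lie within the scatter of each other. Compound 3 `Cc1ccc(S(=O)(=O)N2C/C(=C\c3ccncc3)C(=O)/C(=C/c3ccccc3F)C2)cc1` differs from compound 2 by one change, (methyl in place of hydrogen on an aromatic carbon), which turns phenylsulfonyl into (4-methylphenyl)sulfonyl. Going by the values given here, only one measured step comes near this change: a 1.1-fold higher number from compound 1 to compound 2 (0.03 log units; within the scatter), for phenylsulfonyl in place of methyl on an amine nitrogen in a ring. Among the compounds with values here, no measured step alters the aromatic ring itself, so the evidence is indirect. The whole sulfonyl group made no difference beyond the scatter, and a single added methyl on it is not expected to do more. An estimated 1.1-fold lower number from compound 2 to compound 3 (0.03 log units; within the scatter) is all that is expected, with no shift beyond the scatter in either direction. Compound 3 is thus expected to give 15000 nM with 7500 nM to 30000 nM as the estimated range.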

Compound 3, half-maximal inhibitory concentration: > 20000 nM
Compound 3 was reported as a limit; the forecaster's own chance of this, stated with the estimate: 5%; at least 1.3-fold (0.12 log units) between middle value and limit.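

In this assay compound 3 is reported only as a limit, > 20000 nM. On an aromatic carbon para to a large group, methyl in place of hydrogen gives an at least 1.2-fold higher number from compound 2 to compound 3 (0.09 log units; that floor lies within the scatter), and (4-methylphenyl)sulfonyl in place of methyl on the amine nitrogen gives an at least 1.3-fold higher number from compound 1 to compound 3 (0.12 log units; that floor lies within the scatter). The earlier pair gave a sized step within the scatter, whereas these two steps are floors only, so the methyl on this aromatic ring may have no real effect or a larger one than the floors show, and the reading ends at a limit: the limit of > 20000 nM in this assay, at which 1 of the 3 values shown sits.

The compounds shown leave open how far beyond its limit the true number for compound 3 lies. They also leave open what a methoxy group, a chlorine atom or an amine would do at this ring position.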